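Turning the methylpyridyl group round on a sulfonamide

A few compounds are considered here, and "the series" means these few. Any claim that something is new, unique, unknown or untested is made for them only; others in the source may bear on it.

Compound 1 `Cc1ccc(S(=O)(=O)N(CC(=O)NCc2ccc(Cl)cc2)c2cccnc2)cc1`: in a functional assay on CHO-K1 cells for antagonist activity at prostaglandin E2 receptor EP1 subtype (Homo sapiens), read by FLIPR and calcium flux (a higher number here means a weaker inhibitor, a lower number a stronger inhibitor), compound 1 gives < 1450 nM, which is a limit of the assay, not a number.
Compound 2 `Cc1ccc(S(=O)(=O)N(CC(=O)NCc2ccc(Cl)cc2)c2ccccn2)cc1`: in this assay compound 2 gives < 1450 nM, also a limit of the assay.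
Compound 3 `Cc1ccc(S(=O)(=O)N(CC(=O)NCc2ccc(Cl)cc2)c2cccnc2C)cc1`: in this assay compound 3 gives 676 nM.

Among the compounds with values here, compound 3 therefore holds the only real number of the three; the other two sit at the limit of < 1450 nM in this assay, at which 2 of the 3 values shown sit. For this reason the steps a step that the two limits leave unreadable from compound 1 to compound 2, a step that the limit leaves unreadable from compound 1 to compound 3 and a step that the limit leaves unreadable from compound 2 to compound 3 carry no readable size. Compound 4 `Cc1ccc(S(=O)(=O)N(CC(=O)NCc2ccc(Cl)cc2)c2ncccc2C)cc1` differs from compound 3 in one place: 3-methylpyridin-2-yl in place of 2-methylpyridin-3-yl on a sulfonamide nitrogen. Within the data shown here, no measured step bears on this exchange with a readable size, so in this assay nothing beyond the usual scatter is expected, with an estimated step of a 1.0-fold higher number from compound 3 to compound 4 (0.02 log units; within the scatter). Compound 4 is expected to give about 700 nM, within 250 nM to 2000 nM.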

Compound 4, inhibition constant: < 1450 nM
Compound 4 ended at the assay's limit; the forecaster's own chance of this, stated with the estimate: 30%; the middle value does not contradict the limit.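

No step from compound 1, compound 2 or compound 3 to compound 4 can be read, because compound 4 also gives only a limit: the limit of < 1450 nM in this assay, at which 3 of the 4 values shown sit.

Still open, from the compounds shown here alone, is whether exchanging 2-methylpyridin-3-yl for 3-methylpyridin-2-yl changes this assay at all.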